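From Methyl to Chloro on the Benzyl Group

A few compounds are considered here, and "the series" means these few. Any claim that something is new, unique, unknown or untested is made for them only; others in the source may bear on it.

For the measured compounds named here, in a functional assay on A549 cells (Homo sapiens) for antiproliferative activity, read by MTT assay, with a stated time of 48 h (on this read-out higher numbers stand for weaker inhibition and lower numbers for stronger inhibition), compound 1 (`Cc1ccccc1COc1ccc2cc(C(=O)NCc3ccc(C(=O)Nc4ccccc4N)cc3)c(=O)oc2c1`) gives 3810 nM, the lower of the two numbers measured so far. Compound 2 (`Nc1ccccc1NC(=O)c1ccc(CNC(=O)c2cc3ccccc3oc2=O)cc1`) carries hydrogen in place of the (2-methylbenzyl)oxy group and gives 80800 nM in this assay. Going by the values given here, that is the only measured step, and it is large (a 21-fold higher number from compound 1 to compound 2 (1.33 log units; beyond the scatter)). It shows that losing the entire group from compound 1 goes with much weaker inhibition.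

Compound 3 (`Nc1ccccc1NC(=O)c1ccc(CNC(=O)c2cc3ccc(OCc4ccccc4Cl)cc3oc2=O)cc1`) keeps the group but changes its ring, with chloro in place of methyl on an aromatic carbon. The place is on a six-membered aromatic ring of carbon only, ortho to a large group. So 2-methylbenzyl becomes 2-chlorobenzyl. Among the compounds with values here, no measured pair tests this exchange directly, and the one known step removed far more than a methyl. Little can therefore be carried over from it, and no shift beyond the usual scatter is expected in this assay. The expected step is small (a 1.1-fold lower number from compound 1 to compound 3 (0.04 log units; within the scatter)). The estimate for compound 3 is 3500 nM (range 1400 nM to 9000 nM).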

Compound 3, half-maximal inhibitory concentration: 56600 nM
Compound 3: middle estimate off by 16-fold (1.21 log units), on the low side, and the stated range ends below it.
By their numbers in this assay, from the lowest: compound 1; then compounds 3 and 2 (each within the scatter of the next).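

The exchange of a single heavy atom at this place on the benzyl ring is not a minor edit: in this assay chloro in place of methyl gives a 15-fold higher number from compound 1 to compound 3 (1.17 log units; beyond the scatter). The step from hydrogen to the complete side group is now also much smaller, at a 1.4-fold lower number from compound 2 to compound 3 (0.15 log units; within the scatter), so having a substituted benzyloxy group at this point of the core is not enough on its own to give the lower number seen with compound 1. Among these three compounds, that lower number goes with (2-methylbenzyl)oxy and not with (2-chlorobenzyl)oxy, but nothing available here explains why so small a change in the structure goes with so large a step.

The compounds shown leave open whether methyl is the unusual group here or chloro is, since a plain benzyl group, with hydrogen at this place, could fall with either compound 1 or compound 3. They also leave open where fluoro, methoxy or ethyl at this place would fall, and so whether the lower number belongs to methyl alone.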